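A few compounds are considered here, and "the series" means these few. Any claim that something is new, unique, unknown or untested is made for them only; others in the source may bear on it.

Measured compounds:
Compound 1 `Cc1cc(Cl)ccc1-c1n[nH]c(-c2ccccc2)n1` gives 0.14 mg/kg in a functional assay on the whole organism (Cricetulus griseus) with Cricetinae gen. sp. as the target; a higher number here means that more compound is needed for the effect, a lower number that less compound is needed.
Compound 2 `COc1ccc(-c2n[nH]c(-c3ccccc3)n2)c(C)c1` reaches only the limit of > 10 mg/kg in this assay, at which 1 of the 2 values shown sits, in this assay, so its value > 10 mg/kg is a limit and not a number.

Going by the values given here, compound 2 therefore stands at a limit in this assay, and the only measured step leading to it, an at least 71-fold higher number from compound 1 to compound 2 (1.85 log units; beyond the scatter), is large. Compound 3 `COc1cccc(-c2nc(-c3ccc(OC)cc3C)n[nH]2)c1` differs from compound 2 by methoxy in place of hydrogen on an aromatic carbon. That measured step changed a different ring and gives no direction for this change, so no step beyond the scatter is expected. Compound 3 is expected to stay near the limit, estimated at 15 mg/kg (range 3 mg/kg to 60 mg/kg), an expected step that the limit leaves unreadable from compound 2 to compound 3.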

Compound 3, dose for half-maximal effect: 0.2 mg/kg
Beside the measured number, compound 3's estimate is 75-fold (1.88 log units) above it; measured number outside the range, below it.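

In this assay, methoxy in place of hydrogen on the six-membered aromatic ring of carbon only, meta to a large group, gives an at least 50-fold lower number from compound 2 to compound 3 (1.69 log units; beyond the scatter). The earlier step concerned only the other ring; this one shows that a change at this position alone can carry the series away from the limit, with the methoxy of compound 2 kept. The size of this step remains a bound, as the value of compound 2 is a limit: the limit of > 10 mg/kg in this assay, at which 1 of the 3 values shown sits.

Open, on these data alone, is whether methoxy is specific here, or whether an amine, a carboxylic acid or a longer chain at this position would act alike. Also open, as far as these compounds go, is how this methoxy behaves alongside the chloro of compound 1.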